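The source may report more compounds than this note shows. Statements on the series, on what has been measured and on what is new or still open speak of the compounds shown alone.

Measured in a functional assay on KB cells (Homo sapiens) for cytotoxicity; on this read-out lower numbers stand for stronger inhibition and higher numbers for weaker inhibition:
compound 1 `COc1ccc(S(=O)(=O)N2CCc3cccc(NS(=O)(=O)c4ccc([N+](=O)[O-])cc4)c32)cc1` gives 1100 nM
compound 2 `COc1ccc(S(=O)(=O)N2CCc3cc(Br)cc(NC(=O)c4ccncc4)c32)cc1` gives 91 nM
compound 3 `COc1ccc(S(=O)(=O)N2CCc3cccc(NS(=O)(=O)c4ccc(F)cc4)c32)cc1` gives 1200 nM

Compound 3 has the highest number of the three; compound 1 sits nearest, within the scatter, while compound 2 lies far below it. Among the compounds with values here, the one measured step, a 1.1-fold higher number from compound 1 to compound 3 (0.04 log units; within the scatter), swaps a substituent on an aromatic carbon and is within the scatter. Compound 4 `COc1ccc(S(=O)(=O)N2CCc3cccc(N)c32)cc1` differs from compound 3 by hydrogen in place of (4-fluorophenyl)sulfonyl on a nitrogen on an aromatic ring. Within the data shown here, no measured step removes this group, so the data give no direct guide; the gap between compound 2 and compound 3 involves other parts of the core and does not transfer. Compound 4 is estimated at 3000 nM, with a range from 700 nM to 15000 nM. The expected step, a 2.5-fold higher number from compound 3 to compound 4 (0.40 log units; beyond the scatter) in this assay, leans toward a higher number, with wide uncertainty.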

Compound 4, half-maximal inhibitory concentration: 2800 nM
Compound 4: the middle estimate sits 1.1-fold (0.03 log units) above what was measured, within the range that was stated.
By their numbers in this assay, from the lowest: compound 2; then compounds 1 and 3 (each within the scatter of the next); then compound 4.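

In this assay, taking (4-fluorophenyl)sulfonyl off the nitrogen on the aromatic ring gives a 2.3-fold higher number from compound 3 to compound 4 (0.37 log units; beyond the scatter). Within the data shown here, this is the first measured change at this nitrogen itself, and it moves the number beyond the scatter, whereas the earlier step on the outer ring of the sulfonyl did not. The step is modest, so cytotoxicity persists with only hydrogen at this place, and nothing at hand explains the shift.

Still open, as far as these compounds go, is whether a small acetyl or methyl group on this nitrogen would read closer to compound 3 or to compound 4.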